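The source may hold more compounds than are shown below. What is called first, only, known or untested is meant among the compounds shown, and "the series" means these compounds.

Measured so far:

- compound 1, `Fc1cc2nc(-c3cncnc3C(F)F)n(C3CC3)c2cc1F`: 4330 nM 
- compound 2, `Fc1cc2nc(-c3cncnc3C(F)(F)F)n(C3CC3)c2cc1F`: 4770 nM 
- compound 3, `N#Cc1ccc2nc(-c3cncnc3C(F)F)n(C3CC3)c2c1`: 2040 nM 

These values come from an ADME assay on cells for inhibition of cytochrome P450 11B1, mitochondrial (Homo sapiens), read by HPLC, with a stated time of 60 min; on this read-out lower numbers stand for stronger inhibition and higher numbers for weaker inhibition. Compound 1 and compound 2 share one core and differ only by fluoro in place of hydrogen on a saturated chain carbon bound to an aromatic carbon and two fluorine atoms. That change gave a 1.1-fold higher number from compound 1 to compound 2 (0.04 log units; within the scatter), so the two values are not distinguishable from each other. Compound 3 carries a different core; how its core differs from that of compound 1 is not broken down here. Its value is the lowest of the three, and its gap to compound 1 and to compound 2 lies beyond the scatter.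

Compound 4, `N#Cc1ccc2nc(-c3cncnc3C(F)(F)F)n(C3CC3)c2c1`, stands to compound 3 as compound 2 stands to compound 1: it differs by fluoro in place of hydrogen on a saturated chain carbon bound to an aromatic carbon and two fluorine atoms, on the same kind of carbon, so this is the same change made on the other core. Because the earlier step of a 1.1-fold higher number from compound 1 to compound 2 (0.04 log units; within the scatter) was within the scatter, the step from compound 3 to compound 4 in this assay is expected to be similar, a 1.1-fold higher number from compound 3 to compound 4 (0.04 log units; within the scatter). On that basis, compound 4 is estimated at 2250 nM, with a likely range from 1200 nM to 4500 nM.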

Compound 4, half-maximal inhibitory concentration: 4170 nM
Compound 4: the middle estimate sits 1.9-fold (0.27 log units) below what was measured; low and high end bracket the measured number.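

In this assay, replacing difluoromethyl with trifluoromethyl on the core of compound 3 gave a 2.0-fold higher number from compound 3 to compound 4 (0.31 log units; beyond the scatter), a modest step that, taken alone, points to weaker inhibition. Set beside the same replacement on the core of compound 1, however, this step cannot be told apart from the earlier one: the same change on two cores in this assay, a 1.1-fold higher number (0.04 log units; within the scatter) from compound 1 to compound 2 and a 2.0-fold higher number (0.31 log units; beyond the scatter) from compound 3 to compound 4, 1.9-fold (0.27 log units) apart, within the scatter of two such steps This means the result fits a change that carries from one core to the other with a similar effect, but with only two pairs it does not prove that the effect is the same on both cores, and it does not explain why the two steps look different in size.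

On these data alone, how the number would move with a plain methyl or an amine in place of the difluoromethyl remains open. Also open, as far as these compounds go, is whether a third core, for example one carrying a carboxylic acid, would respond to this replacement in a similar way.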